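Methyl to Methoxy on the Fused Ring of Compound 2

The compounds below may be only part of what the source reports. "The series", "measured", "known", "first", "only" and "open" are said of these compounds alone.

Compound 1 `CS(=O)(=O)c1ccc(Nc2nccc(Nc3nc4ccccc4s3)n2)cc1` is the simplest member of the set; in a functional assay on PC-3 cells (Homo sapiens) for antiproliferative activity, read by MTT assay, with a stated time of 48 h (on this read-out higher numbers stand for weaker inhibition and lower numbers for stronger inhibition), compound 1 gives 1710 nM. Compound 2 `Cc1ccc2nc(Nc3ccnc(Nc4ccc(S(C)(=O)=O)cc4)n3)sc2c1` carries a methyl on the shared core. For compound 2 the reading is a limit of the assay, > 50000 nM, not a number. Compound 2 thus sits at the limit of > 50000 nM in this assay, at which 1 of the 3 values shown sits, the weak end of what was measured. Compound 3 `Cc1ccc2nc(Nc3ccnc(Nc4ccc(S(N)(=O)=O)cc4)n3)sc2c1` gives 1640 nM. The step of an at least 29-fold higher number from compound 1 to compound 2 (1.46 log units; beyond the scatter) shows how much the methyl cost, and the step of an at least 30-fold lower number from compound 2 to compound 3 (1.48 log units; beyond the scatter) shows how much the sulfonamide restored.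

Compound 4 `COc1ccc2nc(Nc3ccnc(Nc4ccc(S(C)(=O)=O)cc4)n3)sc2c1` differs from compound 2 by methoxy in place of methyl on an aromatic carbon. Among the compounds with values here, no measured step swaps methyl for methoxy at this place, so the two measured steps bear on it only indirectly, both being large and both starting or ending at compound 2. Since compound 2 is a limit, any step to compound 4 is visible only if compound 4 returns to the measurable range. Compound 4 is expected to remain weak, with a step of an at least 1.6-fold lower number from compound 2 to compound 4 (0.22 log units; that floor lies within the scatter). The estimate for compound 4 in this assay is 30000 nM, expected between 8000 nM and 100000 nM.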

Compound 4, half-maximal inhibitory concentration: 2700 nM
For compound 4 the middle estimate is 11-fold (1.05 log units) above the measured one; the measured number lies below the stated range.
By their numbers in this assay, from the lowest: compounds 3, 1 and 4 (each within the scatter of the next). At a limit, above all of these: compound 2.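

Swapping the methyl for methoxy at this position gives an at least 18-fold lower number from compound 2 to compound 4 (1.26 log units; beyond the scatter) in this assay, so having a group here does not by itself abolish activity; the outcome depends on which group it is. Set against compound 1, which has only hydrogen at this place, methoxy gives a 1.6-fold higher number from compound 1 to compound 4 (0.20 log units; within the scatter), meaning that methoxy is tolerated here while methyl is not. The size of the first step is only a floor, because compound 2 reads as a limit: the limit of > 50000 nM in this assay, at which 1 of the 4 values shown sits.

The compounds shown do not explain why two such small groups part so sharply, nor whether the methyl is the exception here. An amine, a chlorine or a longer ether such as ethoxy at this position could tell, as could pairing methoxy with the sulfonamide of compound 3.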